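Replacing the chlorophenyl ring on the amide nitrogen with pyrimidinyl

The compounds below may be only part of what the source reports. "The series", "measured", "known", "first", "only" and "open" are said of these compounds alone.

Measured compounds:
compound 1 `CO[C@@H]1CC=C2NN(c3ccc(Cl)cc3)C(=O)C[C@]2(C)O1`, 35700 nM
compound 2 `CO[C@@H]1CC=C2NN(c3cc(Cl)cc(Cl)c3)C(=O)C[C@]2(c2ccncc2)O1`, 9100 nM
compound 3 `COc1cc(OC)cc(N2NC3=CC[C@@H](OC)O[C@@]3(c3ccncc3)CC2=O)c1`, 6500 nM

In a functional assay on HCT-116 cells (Homo sapiens) for inhibition, read by sulforhodamine B assay, with a stated time of 48 h (on this read-out lower numbers stand for stronger inhibition and higher numbers for weaker inhibition), compound 1 gives the highest of the three numbers, so it is the weakest inhibitor here; the nearest is compound 2, with a lower number beyond the scatter, and compound 3 is lower still. Compound 4 `CO[C@@H]1CC=C2NN(c3cncnc3)C(=O)C[C@]2(C)O1` differs from compound 1 in one place: pyrimidin-5-yl in place of 4-chlorophenyl on an amide-type nitrogen in a ring. Going by the values given here, no pair among the measured compounds isolates a change of this aryl group alone, so the expectation rests on compound 1 by itself. The estimated step from compound 1 to compound 4 in this assay is a 1.4-fold higher number from compound 1 to compound 4 (0.15 log units; within the scatter), toward weaker inhibition but of a size that may sit within the scatter. Compound 4 is expected to give about 50000 nM, in a range from 15000 nM to 150000 nM.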

Compound 4, half-maximal inhibitory concentration: 15100 nM
Compound 4: middle estimate off by 3.3-fold (0.52 log units), on the high side; the range from low to high includes it.
By their numbers in this assay, from the lowest: compounds 3, 2 and 4 (each within the scatter of the next, the first and the last beyond it); then compound 1.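

In this assay, pyrimidin-5-yl in place of 4-chlorophenyl on the amide-type nitrogen gives a 2.4-fold lower number from compound 1 to compound 4 (0.37 log units; beyond the scatter) and so a modest gain in inhibition. The earlier compounds shown here carry only substituted phenyl rings at this nitrogen, so they could not show that a ring with hetero atoms and no chlorine is accepted here. On these data alone, whether an aminophenyl ring would do better at this nitrogen, and whether the same swap holds on the core of compound 3, stays open. No measurement shown here explains the gain.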